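Vinyl to 4-methylphenyl exchange in a three-compound series

A few compounds are considered here, and "the series" means these few. Any claim that something is new, unique, unknown or untested is made for them only; others in the source may bear on it.

Measured so far in a functional assay on MCF7 cells (Homo sapiens) for inhibition, read by sulforhodamine B assay, with a stated time of 48 h; a higher number here means a weaker inhibitor, a lower number a stronger inhibitor:
compound 1 `COc1ccc(C(O)(Cc2ccc(C)cc2)c2cccc3ccccc23)c(OC)c1OC`: > 20000 nM, a limit of the assay.
compound 2 `C=CCC(O)(c1ccc(OC)c(OC)c1OC)c1cccc2ccccc12`: > 20000 nM, a limit of the assay.
compound 3 `C=CCOC(c1ccc(OC)c(OC)c1OC)c1cccc2ccccc12`: > 20000 nM, a limit of the assay.

Every value in this assay stands at the limit of > 20000 nM in this assay, at which 3 of the 3 values shown sit, so none of the three compounds gives a number. Compound 2 and compound 1 differ by 4-methylphenyl in place of vinyl on a saturated chain carbon, two bonds along the chain from two aromatic carbons and an oxygen on a saturated carbon, and because both sit at the limit of > 20000 nM in this assay, at which 3 of the 3 values shown sit, the step that the two limits leave unreadable from compound 2 to compound 1 cannot be read. Compound 3 and compound 2 have the same atoms joined differently; the difference between the two cores is not broken down here.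

Compound 4 `COc1ccc(C(OCc2ccc(C)cc2)c2cccc3ccccc23)c(OC)c1OC` is not yet measured. It differs from compound 3 by 4-methylphenyl in place of vinyl on a saturated chain carbon bound to an oxygen on a saturated carbon. This is the same kind of change as that from compound 2 to compound 1, but the place differs: in compound 4 the saturated chain carbon is bound to an oxygen on a saturated carbon, whereas in compound 1 it lies two bonds along the chain from two aromatic carbons and an oxygen on a saturated carbon. The earlier step left no readable size, and the starting point compound 3 is itself only a limit, so the expectation for compound 4 rests on the fact that all three measured compounds sit at the limit of > 20000 nM in this assay, at which 3 of the 3 values shown sit. The step expected for compound 4 in this assay is a step that the limit leaves unreadable from compound 3 to compound 4, set beside the unreadable earlier one. Compound 4 is therefore estimated at 30000 nM, with a range from 8000 nM to 100000 nM, and it is most likely to be reported again only as a limit.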

Compound 4, half-maximal inhibitory concentration: 10700 nM
Compound 4: middle estimate off by 2.8-fold (0.45 log units), on the high side; measured number inside the range.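

In this assay, within the data shown here, compound 4 gives 10700 nM, the only value that is a number and not a limit. As far as these compounds go, with 4-methylphenyl in place of vinyl on a saturated chain carbon bound to an oxygen on a saturated carbon, the result is an at least 1.8-fold lower number from compound 3 to compound 4 (0.27 log units; that floor lies within the scatter); this figure is only a floor, its true size is unknown, and the floor alone does not establish a real gain. The same exchange on the core of compound 2 and compound 1 cannot be read, so the data do not show whether the change carries from one core to the other, and the two steps cannot be compared in size: the limit of > 20000 nM in this assay, at which 3 of the 4 values shown sit.

Still open, from the compounds shown here alone, is whether the result belongs to 4-methylphenyl itself or would also appear with another group at this place, such as an unsubstituted phenyl, a 4-methoxyphenyl or a longer saturated chain ending in an amine or a carboxylic acid. Also open, going by these compounds, is how much of the result depends on the core of compound 4 as opposed to the core of compound 1, which carries the hydroxyl group on its saturated carbon.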